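Methoxy for Methyl: Expected Solubility of Compound 3

The compounds below may be only part of what the source reports. "The series", "measured", "known", "first", "only" and "open" are said of these compounds alone.

Measured so far:
Compound 1 `CC(C)Nc1nc(NCc2ccco2)c2ccccc2n1` — in a physicochemical assay for solubility, at pH 7.4 (a higher number here means a more soluble compound, a lower number a less soluble compound), compound 1 gives >= 30000 nM, a limit of the assay.
Compound 2 `Cc1cccc2c(NCc3ccco3)nc(NC(C)C)nc12` — in this assay compound 2 gives <= 20000 nM, again a limit.

Compound 2 therefore stands only at a limit (the limit of <= 20000 nM in this assay, at which 1 of the 2 values shown sits); compound 1 sits at the other (the limit of >= 30000 nM in this assay, at which 1 of the 2 values shown sits). Among the measured compounds shown here, the single measured step, an at least 1.5-fold lower number from compound 1 to compound 2 (0.17 log units; that floor lies within the scatter), is the methyl for hydrogen change. Compound 3 `COc1cccc2c(NCc3ccco3)nc(NC(C)C)nc12` differs from compound 2 by methoxy in place of methyl on an aromatic carbon. For the measured compounds named here, no measured step covers a methoxy; the one step in hand is small. Compound 3 is expected near compound 2, at 20000 nM (range 7000 nM to 50000 nM), an estimated step of a number no lower from compound 2 to compound 3 (the limit leaves the size open).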

Compound 3, solubility: <= 20000 nM
Compound 3: no number, only a limit (the forecaster's own chance of this, stated with the estimate: 50%); the middle value lies on the limit itself.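

In this assay compound 3 gives <= 20000 nM, which is a limit and not a number. Methoxy in place of hydrogen on this aromatic carbon gives an at least 1.5-fold lower number from compound 1 to compound 3 (0.17 log units; that floor lies within the scatter), so the position now has a second group with a read-out at a limit. The step between compound 2 and compound 3 cannot be read, and methoxy and methyl share one limit: the limit of <= 20000 nM in this assay, at which 2 of the 3 values shown sit.

On these data alone, whether methoxy and methyl differ here remains open, as do the true values of both compounds. So does the read-out with an amine or a carboxylic acid on this aromatic carbon.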